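Sulfonyl aryl variation on the shared core: a bulkier para substituent

The compounds below may be only part of what the source reports. "The series", "measured", "known", "first", "only" and "open" are said of these compounds alone.

Three compounds on the shared core carry different aryl groups on the sulfonyl sulfur. Compound 1 `COc1cc2nc(N3CCN(S(=O)(=O)c4ccc(Cl)s4)CC3)nc(N)c2cc1OC` gives 25000 nM in a functional assay on PC-3 cells (Homo sapiens) for inhibition; a lower number here means a stronger inhibitor, a higher number a weaker inhibitor. Compound 2 `COc1cc2nc(N3CCN(S(=O)(=O)c4ccc(C(F)(F)F)cc4)CC3)nc(N)c2cc1OC` gives 27000 nM in this assay, the highest of the three numbers, yet its nearest neighbour compound 1 is only a 1.1-fold higher number from compound 1 to compound 2 (0.03 log units; within the scatter) away and compound 3 `COc1cc2nc(N3CCN(S(=O)(=O)c4cccc5ccccc45)CC3)nc(N)c2cc1OC`, with 14000 nM in this assay, is a 1.9-fold lower number from compound 2 to compound 3 (0.29 log units; within the scatter) away, so none of the three is separated from another beyond the scatter; a 1.8-fold lower number from compound 1 to compound 3 (0.25 log units; within the scatter) completes the picture.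

Compound 4 `CCCCc1ccc(-c2ccc(S(=O)(=O)N3CCN(c4nc(N)c5cc(OC)c(OC)cc5n4)CC3)cc2)cc1` is not yet measured. From compound 2 it differs by 4-butylphenyl in place of trifluoromethyl on an aromatic carbon, on an aromatic carbon of a six-membered aromatic ring of carbon only, para to a large group. For the measured compounds named here, the only step that bears on a change of the group on the sulfonyl aryl is compound 2 to compound 3, which was within the scatter, as were the other two steps. Nothing measured here separates a small group from a large one on this part of the molecule, so the step of a 1.4-fold lower number from compound 2 to compound 4 (0.13 log units; within the scatter) is expected to stay within the scatter, with at most a slight lean toward a lower number. For compound 4 the estimate in this assay is 20000 nM, with a range from 7000 nM to 60000 nM.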

Compound 4, half-maximal inhibitory concentration: 3400 nM
Beside the measured number, compound 4's estimate is 5.9-fold (0.77 log units) above it; the measured number lies below the stated range.
By their numbers in this assay, from the lowest: compound 4; then compounds 3, 1 and 2 (each within the scatter of the next).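

In this assay, for the compounds shown here, 4-butylphenyl in place of trifluoromethyl on an aromatic carbon, para to a large group, gives a 7.9-fold lower number from compound 2 to compound 4 (0.90 log units; beyond the scatter) and is the first step to lie beyond the scatter, whereas all three steps among compounds 1, 2 and 3 stayed within it. Exchanging one sulfonyl aryl group for another had not separated those compounds, but this change to the group on the aryl ring does move the number, so this position is not indifferent to what it carries. The change adds a six-membered aromatic ring of carbon only and a butyl chain together, with no hydrogen-bond donors or acceptors on either the entering or the leaving group, and no measured evidence on the cause of the step is at hand.

The compounds shown leave open whether the added ring, the butyl chain or the two together go with the lower number, a question that a plain phenyl group or a hexyl chain in the same place would address. They also leave open how the number responds to an amine or a carboxylic acid at the end of the chain.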